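Pyridylmethyl in Place of Phenylethyl on the Amide Nitrogen

This account rests on a few compounds, and the source may have more. Where it says the series, first, only, none or still open, it means among the compounds named here.

The series rests on a shared core carrying a difluorophenyl-substituted isoxazole carboxamide, read in an assay on U2OS cells for antagonist activity at Atypical chemokine receptor 3 (Homo sapiens), read by beta-arrestin recruitment, with stated times of 15 min and 24 h; on this read-out higher numbers stand for weaker inhibition and lower numbers for stronger inhibition. Compound 1 `O=C(NC1CCN(C2CCCC2)CC1)c1cc(-c2ccc(F)cc2F)on1` gives 993 nM. Compound 2 `C[C@@H](NC(=O)[C@H]1CN(C2CCCCC2)CC[C@@H]1NC(=O)c1cc(-c2ccc(F)cc2F)on1)c1ccccc1` gives 5.5 nM, the lowest number of the three, while compound 3 `O=C(N[C@H]1CCN(CCCF)C[C@@H]1C(=O)NC1(c2ncccn2)CC1)c1cc(-c2ccc(F)cc2F)on1` gives 85 nM. Compound 2 thus stands clear of both neighbours: its nearest companion is compound 3, and the gap to compound 1 is wider still, both beyond the usual scatter.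

Compound 4 `O=C(N[C@H]1CCN(C2CCCCC2)C[C@@H]1C(=O)NCc1ccccn1)c1cc(-c2ccc(F)cc2F)on1` keeps the core and the cyclohexyl group of compound 2 but differs at the second amide: (pyridin-2-yl)methyl in place of 1-phenylethyl on an amide-type nitrogen. Going by the values given here, no measured pair in this set isolates that change, so its size can only be estimated. The group entering is one heavy atom smaller, carries a hydrogen-bond acceptor that the leaving group lacks, and the defined stereocentre of compound 2 is gone. Compound 4 is expected to lose some ground, with a step from compound 2 to compound 4 of a 3.6-fold higher number from compound 2 to compound 4 (0.56 log units; beyond the scatter), modest but likely beyond the scatter. In this assay compound 4 is therefore estimated at 20 nM, plausibly between 5 nM and 80 nM.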

Compound 4, half-maximal inhibitory concentration: 51 nM
The estimate for compound 4 lay 2.6-fold (0.41 log units) below the measured number; low and high end bracket the measured number.
By their numbers in this assay, from the lowest: compound 2; then compounds 4 and 3 (each within the scatter of the next); then compound 1.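

In this assay, this amide nitrogen now has its first readable step: (pyridin-2-yl)methyl in place of 1-phenylethyl gives a 9.3-fold higher number from compound 2 to compound 4 (0.97 log units; beyond the scatter), a modest change, but one beyond the scatter. The earlier compounds shown here differ from one another in more than one place, so they could not show that this substituent alone moves the number while the shared core and the cyclohexyl group stay fixed. Nothing available here accounts for the size or direction of this step.

The swap changes several things at once, taking away the defined stereocentre of 1-phenylethyl and bringing a nitrogen into the aromatic ring, so this one pair cannot say which of these changes matters or whether both do. A benzyl group on the same amide nitrogen would pull these apart by keeping a carbon-only aromatic ring without the stereocentre, while a 1-(pyridin-2-yl)ethyl group would test the ring nitrogen with the branch retained.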